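Swapping the Ring on the Amine Nitrogen

A few compounds are considered here, and "the series" means these few. Any claim that something is new, unique, unknown or untested is made for them only; others in the source may bear on it.

Compound 2 `CC1=C(N2C[C@@H](O[C@H](C)c3cc(C(F)(F)F)cc(C(F)(F)F)c3)[C@H](c3ccc(F)cc3)C2)CCC1=O` in an assay on CHO cells for displacement of a labelled ligand from Substance-P receptor (Homo sapiens) (on this read-out higher numbers stand for weaker inhibition and lower numbers for stronger inhibition), gives 0.13 nM, and compound 1 `CC(C)C(=O)N1C[C@@H](O[C@H](C)c2cc(C(F)(F)F)cc(C(F)(F)F)c2)[C@H](c2ccc(F)cc2)C1` gives 0.15 nM; the step of a 1.2-fold lower number from compound 1 to compound 2 (0.06 log units; within the scatter) lies within the scatter, so the two numbers cannot be told apart. Compound 3 `C[C@@H](O[C@@H]1CN(C2=CC(=O)OC2)C[C@H]1c1ccc(F)cc1)c1cc(C(F)(F)F)cc(C(F)(F)F)c1` has not yet been measured. It differs from compound 2 by a group of 6 heavy atoms (4 carbon, 2 oxygen; one five-membered non-aromatic ring with 1 hetero atom) in place of a group of 7 heavy atoms (6 carbon, 1 oxygen; one five-membered non-aromatic ring of carbon only), on an amine nitrogen in a ring. Going by the values given here, the one measured step, a 1.2-fold lower number from compound 1 to compound 2 (0.06 log units; within the scatter), also replaced the group on that same nitrogen and barely moved the number. For compound 3 no step beyond the scatter is therefore expected, a 1.5-fold higher number from compound 2 to compound 3 (0.19 log units; within the scatter). Compound 3 is estimated at 0.2 nM, within a range from 0.07 nM to 0.6 nM.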

Compound 3, half-maximal inhibitory concentration: 0.16 nM
Compound 3: the middle estimate sits 1.3-fold (0.10 log units) above what was measured; the measured number falls inside the stated range.
By their numbers in this assay, from the lowest: compounds 2, 1 and 3 (each within the scatter of the next).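

A third group on the amine nitrogen, this one with a hetero atom in its five-membered ring, gives the same picture in this assay: the steps, a 1.2-fold higher number from compound 2 to compound 3 (0.09 log units; within the scatter) and a 1.1-fold higher number from compound 1 to compound 3 (0.03 log units; within the scatter), stay within the scatter. Isopropylcarbonyl and two different ring groups, one with 1 hydrogen-bond acceptor and one with 2, thus give numbers that cannot be told apart. Nothing measured here bears on why the number holds. Going by these compounds, whether a group carrying an amine, a carboxylic acid or a longer chain on this nitrogen would also leave the number in place stays open.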